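The source may report more compounds than this note shows. Statements on the series, on what has been measured and on what is new or still open speak of the compounds shown alone.

Compound 1 `Cc1ccsc1C(=O)OC(CCN(C)C)c1ccc(Cl)cc1` gives 119% in an assay on NIH3T3 cells with Urotensin-2 receptor (Homo sapiens) as the target; a lower number here means a smaller maximal response, a higher number a larger maximal response.
Compound 2 `CN(C)CCC(OC(=O)c1ccc(C(F)(F)F)cc1)c1ccc(Cl)cc1` gives 47% in this assay.
Compound 3 `CN(C)CCC(OC(=O)c1ccc2ccccc2c1)c1ccc(Cl)cc1` gives 49% in this assay.

Among these three compounds, compound 1 stands highest in this assay. Its nearest neighbour is compound 3, whose number lies well below it, beyond the usual scatter; compound 2 lies lower still, also beyond the scatter. The values of compound 2 and compound 3 fall within the scatter of each other, so nothing separates those two.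

Compound 4 `Cc1ccc(C)c(C(=O)OC(CCN(C)C)c2ccc(Cl)cc2)c1` has not yet been measured. It differs from compound 1 in one place: 2,5-dimethylphenyl in place of 3-methylthiophen-2-yl on a carbonyl carbon. The two compounds with a carbon-only aromatic ring on the ester carbonyl, compound 2 and compound 3, both sit far below compound 1, which carries the five-membered ring. That points toward a drop for compound 4, though the 2,5-dimethylphenyl group is not the same as either of those rings, so the size of the drop is uncertain. The expected step from compound 1 to compound 4 is a number 44 percentage points lower from compound 1 to compound 4 (beyond the scatter), a decrease beyond the scatter. Compound 4 is therefore estimated at 75% in this assay, within the range 40% to 120%.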

Compound 4, largest response reached (reported as efficacy), in percent of the reference or control that the assay uses: 86%
Compound 4: middle estimate off by 11 percentage points, on the low side, within the range that was stated.
By their numbers in this assay, from the lowest: compounds 2 and 3 (each within the scatter of the next); then compound 4; then compound 1.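

In this assay, putting 2,5-dimethylphenyl in place of 3-methylthiophen-2-yl on the carbonyl carbon gives a large step, a number 33 percentage points lower from compound 1 to compound 4 (beyond the scatter), so this position responds to the exchange of one ring for the other. A carbon-only ring here does not by itself bring the number down to the level of the other two: compound 4 gives 86%, whereas compound 2 gives 47% and compound 3 gives 49%. No evidence at hand speaks to what lies behind this step.

The compounds shown leave open whether the step belongs to the change of ring itself or to the two methyl groups on it, and how an unsubstituted phenyl or a furan-2-yl ring would stand at this carbonyl carbon. As far as these compounds go, the effect of replacing the dimethylamino group with a pyrrolidine also remains open.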